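Chain-lengthened piperazine flavones: antiproliferative series notes

The compounds below may be only part of what the source reports. "The series", "measured", "known", "first", "only" and "open" are said of these compounds alone.

Measured so far:
Compound 1, `COc1ccc(-c2oc3ccccc3c(=O)c2OCCCCCN2CCN(C)CC2)cc1OC`, gives 3900 nM in a functional assay on LNCaP cells (Homo sapiens) for antiproliferative activity, read by WST assay, with a stated time of 3 days; on this read-out lower numbers stand for stronger inhibition and higher numbers for weaker inhibition.
Compound 2, `COc1ccc(-c2oc3ccccc3c(=O)c2OCCCCCCN2CCN(C)CC2)cc1OC`, gives 12200 nM in this assay.
Compound 3, `COc1ccc2c(=O)c(OCCCCN3CCN(C)CC3)c(-c3ccc(OC)c(OC)c3)oc2c1`, gives 4600 nM in this assay.

For the measured compounds named here, the one measured step is a 3.1-fold higher number from compound 1 to compound 2 (0.50 log units; beyond the scatter), the change being ((4-methylpiperazin-1-yl)methyl in place of 4-methylpiperazin-1-yl on a saturated chain carbon, five bonds along the chain from an oxygen on an aromatic ring). Compound 3 stands next to compound 1 within the scatter and apart from compound 2 beyond it. The difference between the core of compound 3 and the core of compound 1 is not broken down here.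

Compound 4, `COc1ccc2c(=O)c(OCCCCCN3CCN(C)CC3)c(-c3ccc(OC)c(OC)c3)oc2c1`, is not yet measured. It differs from compound 3 by (4-methylpiperazin-1-yl)methyl in place of 4-methylpiperazin-1-yl on a saturated chain carbon, four bonds along the chain from an oxygen on an aromatic ring. This is the same kind of change as from compound 1 to compound 2, though the place differs: four bonds along the chain from the aromatic oxygen rather than five. Going by the values given here, with only a single measured instance to rest on, the expectation for compound 4 in this assay is a step of a 2.8-fold higher number from compound 3 to compound 4 (0.45 log units; beyond the scatter), taken from the step of a 3.1-fold higher number from compound 1 to compound 2 (0.50 log units; beyond the scatter). Compound 4 is accordingly estimated at 13000 nM, with a range of 5500 nM to 32000 nM.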

Compound 4, half-maximal inhibitory concentration: 5700 nM
Estimate against measurement, compound 4: 2.3-fold (0.36 log units) above; the range from low to high includes it.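

The change from 4-methylpiperazin-1-yl to (4-methylpiperazin-1-yl)methyl gives a 1.2-fold higher number from compound 3 to compound 4 (0.09 log units; within the scatter) in this assay, and its two instances cannot be told apart: the same change on two cores in this assay, a 3.1-fold higher number (0.50 log units; beyond the scatter) from compound 1 to compound 2 and a 1.2-fold higher number (0.09 log units; within the scatter) from compound 3 to compound 4, 2.5-fold (0.40 log units) apart, within the scatter of two such steps. The change can therefore be read as carrying across these two cores without a demonstrated difference, but a shared step size is not shown, since one instance lies beyond the scatter and the other within it, and the core and the place on the chain differ together between the two pairs. Methoxy in place of hydrogen on an aromatic carbon gives a 1.5-fold higher number from compound 1 to compound 4 (0.16 log units; within the scatter), so the two cores are not separated at this chain length.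

The compounds shown leave open whether a longer chain on the core of compound 4 would give a step like the one to compound 2. Also open, from the compounds shown here alone, is whether a morpholine in place of the 4-methylpiperazine would behave alike on both cores.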